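The source may hold more compounds than are shown below. What is called first, only, known or untested is meant among the compounds shown, and "the series" means these compounds.

Within the data shown here, compound 3 `COc1cccc(OC)c1OCCNCCOc1ccccc1OCc1ccccc1[N+](=O)[O-]` gives 95500 nM in a functional assay on PC-3 cells (Homo sapiens) for cytotoxicity, read by sulforhodamine B assay (a higher number here means that more compound is tolerated, a lower number that less compound is tolerated), at the top of the three numbers measured so far, though compound 2 `COc1cccc(OC)c1OCCNCCOc1ccccc1OCc1cccc(C)c1` with 87100 nM and compound 1 `COc1cccc(OC)c1OCCNCCOc1ccccc1OCc1ccc(Cl)cc1` with 52500 nM both fall within the scatter of it. Compound 4 `CCOc1ccc(COc2ccccc2OCCNCCOc2c(OC)cccc2OC)cc1` differs from compound 3 by 4-ethoxyphenyl in place of 2-nitrophenyl on a saturated chain carbon bound to an oxygen on an aromatic ring. The earlier swaps at this same place bear on the step: a 1.8-fold higher number from compound 1 to compound 3 (0.26 log units; within the scatter), a 1.1-fold higher number from compound 2 to compound 3 (0.04 log units; within the scatter) and a 1.7-fold higher number from compound 1 to compound 2 (0.22 log units; within the scatter), none of them beyond the scatter. Three different groups at this position therefore gave the same read-out within scatter, and for compound 4 no step beyond the scatter is expected in either direction, a 1.1-fold lower number from compound 3 to compound 4 (0.05 log units; within the scatter). Compound 4 is estimated at 85000 nM, with a range from 40000 nM to 180000 nM.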

Compound 4, concentration lethal to 50% of the cells: 51300 nM
For compound 4 the middle estimate is 1.7-fold (0.22 log units) above the measured one; the range from low to high includes it.
By their numbers in this assay, from the lowest: compounds 4, 1, 2 and 3 (each within the scatter of the next).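

A fourth group at this position, 4-ethoxyphenyl, also stays within the scatter of the other three (a 1.9-fold lower number from compound 3 to compound 4 (0.27 log units; within the scatter)), (a 1.7-fold lower number from compound 2 to compound 4 (0.23 log units; within the scatter)), (a 1.0-fold lower number from compound 1 to compound 4 (0.01 log units; within the scatter)). The last step, ethoxy in place of chloro on an aromatic carbon, leaves the number practically unmoved, so this assay separates none of the four groups. No measurement at hand accounts for this flat read-out.

Still open, going by these compounds, is whether an amine or a carboxylic acid at this position would move the number beyond the scatter. Equally open, on these data alone, is whether any change elsewhere in the shared core would do so.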